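This account rests on a few compounds, and the source may have more. Where it says the series, first, only, none or still open, it means among the compounds named here.

Compound 1 `Oc1ccc2[nH]ncc2c1C(c1ccc(-c2cncnc2)cc1)N1CCCCC1` and compound 2 `Oc1c(C(c2ccc(F)cc2)N2CCCCC2)ccc2cccnc12` were tested in an assay for inhibition of protein disulfide-isomerase (Homo sapiens), with a stated time of 1 h; on this read-out lower numbers stand for stronger inhibition and higher numbers for weaker inhibition. In this assay compound 1 gives 830 nM, and compound 2 gives 690 nM. These two numbers lie within the usual scatter of each other, so neither compound can be set apart from the other on this read-out; compound 1 simply has the higher of the two figures.

Compound 3 `Oc1ccc2[nH]ncc2c1C(c1ccc(C(F)(F)F)cc1)N1CCCCC1` has not yet been measured in this assay. It differs from compound 1 in one place: trifluoromethyl in place of pyrimidin-5-yl on an aromatic carbon. Among the compounds with values here, no step between two measured compounds covers such a change, so there is nothing here to show how large its effect should be. Compound 2 carries a fluorine in the same position of its own ring and gives a number near that of compound 1, which offers only loose guidance. The step from compound 1 to compound 3 is therefore expected to be small, a 1.2-fold higher number from compound 1 to compound 3 (0.08 log units; within the scatter), with no direction firmly indicated beyond the scatter. Compound 3 is estimated at 1000 nM, within a range from 300 nM to 3500 nM.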

Compound 3, half-maximal inhibitory concentration: 710 nM
Beside the measured number, compound 3's estimate is 1.4-fold (0.15 log units) above it, within the range that was stated.
By their numbers in this assay, from the lowest: compounds 2, 3 and 1 (each within the scatter of the next).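

In this assay, putting trifluoromethyl in place of pyrimidin-5-yl, on an aromatic carbon para to a large group, gives a 1.2-fold lower number from compound 1 to compound 3 (0.07 log units; within the scatter). Between compound 1 and compound 3, then, an aromatic ring with hydrogen-bond acceptors gives way to a group with no ring and no hydrogen-bond acceptors, and this read-out cannot tell the two compounds apart, so neither that ring nor its acceptors are needed to keep the number at this position. Nothing measured here explains why two such different groups give such similar numbers.

Still open, as far as these compounds go, is whether an amine or a carboxylic acid at this position would move the number beyond the scatter. Also open, from the compounds shown here alone, is whether a lone fluorine on the core of compound 1 would give a similar number.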